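This account rests on a few compounds, and the source may have more. Where it says the series, first, only, none or still open, it means among the compounds named here.

In a functional assay on HL-60 cells (Homo sapiens) for antiproliferative activity, read by XTT assay, with a stated time of 72 h (on this read-out higher numbers stand for weaker inhibition and lower numbers for stronger inhibition), two compounds sharing a common core have been measured. Compound 1 (`C=C(C)CC[C@]1(C)C2=CCC[C@](C)(C[C@H](O)c3ccoc3)[C@H]2CC[C@H]1C`) gives 28700 nM, and compound 2 (`C=C(C)CCC[C@]1(C)C2=CCC[C@](C)(C[C@@H](O)c3ccoc3)[C@H]2CC[C@H]1C`) gives 31200 nM. These two numbers lie within the usual scatter of repeated measurements, so compound 2 cannot be ranked apart from compound 1.

Compound 3 (`C=C(C)CC[C@]1(C)C2=CCC[C@](C)(C[C@@H](O)c3ccoc3)[C@H]2CC[C@H]1C`) keeps the structure of compound 2 except for one change: 1-methylethenyl in place of 2-methylprop-2-en-1-yl on a saturated chain carbon, two bonds along the chain from a saturated ring carbon. Within the data shown here, no measured pair shows this change on its own, so the only guide is the narrow spread of the two known values. In this assay, the estimated step of a 1.1-fold lower number from compound 2 to compound 3 (0.03 log units; within the scatter) is expected to stay within the scatter. Compound 3 is expected to give about 29000 nM, with an estimated range of 15000 nM to 55000 nM.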

Compound 3, half-maximal inhibitory concentration: 28700 nM
Estimate against measurement, compound 3: 1.0-fold (0.00 log units) above, within the range that was stated.
By their numbers in this assay, from the lowest: compounds 1, 3 and 2 (each within the scatter of the next).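

In this assay, setting 1-methylethenyl in place of 2-methylprop-2-en-1-yl on a saturated chain carbon, two bonds along the chain from a saturated ring carbon, gives a 1.1-fold lower number from compound 2 to compound 3 (0.04 log units; within the scatter), so this swap can now be read on its own and does not separate the two compounds. Among these compounds, the stereocentre at a saturated chain carbon can also be read for the first time, drawn S in compound 1 and R in compound 3, and the step is no change at the digits printed from compound 1 to compound 3 (within the scatter). This second comparison isolates the drawn configuration, and what allows that is this: the fact that compounds 1 and 3 differ only in the configuration as drawn

From the compounds shown here alone, it remains open whether an amine, a carboxylic acid or a longer chain in this place would move the number beyond the scatter. Going by these compounds, how changes elsewhere on the shared core would read in this assay also remains open.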